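The source may hold more compounds than are shown below. What is called first, only, known or untested is meant among the compounds shown, and "the series" means these compounds.

Among the compounds with values here, in a functional assay on PC-3 cells (Homo sapiens) for cytotoxicity, read by MTT assay, with a stated time of 72 h (on this read-out lower numbers stand for stronger inhibition and higher numbers for weaker inhibition), two compounds carry numbers so far. Within the data shown here, compound 2 (`COc1cc2ncnc(Nc3ccc(F)c(Cl)c3)c2cc1NC(=O)N/N=C/c1ccc(C#N)cc1`) reads 36500 nM and compound 1 (`O=C(N/N=C/c1cccc(Cl)c1Cl)Nc1cc2c(Nc3ccc(F)c(Cl)c3)ncnc2cc1O[C@H]1CCOC1`) reads 27400 nM in the same assay, so the two lie within the scatter of each other and compound 2 stands level with the only other measured compound. Compound 3 (`COc1cc2ncnc(Nc3ccc(F)c(Cl)c3)c2cc1NC(=O)N/N=C/c1cccc(Cl)c1Cl`) differs from compound 2 in one place: 2,3-dichlorophenyl in place of 4-cyanophenyl on a carbon with a double bond to nitrogen in words, 2,3-dichlorophenyl in place of 4-cyanophenyl on a carbon with a double bond to nitrogen. Among the measured compounds shown here, no measured pair isolates this change, so no step of its size is known. For the measured compounds named here, the only guide is compound 1, which bears the same 2,3-dichlorophenyl and gives 27400 nM in this assay on a different core. A step beyond the scatter is therefore not expected. The estimated 1.2-fold lower number from compound 2 to compound 3 (0.09 log units; within the scatter) is expected to stay within the scatter. For compound 3 the expected value is 30000 nM with an estimated range from 14000 nM to 60000 nM in this read-out.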

Compound 3, half-maximal inhibitory concentration: 24400 nM
The estimate for compound 3 lay 1.2-fold (0.09 log units) above the measured number; the range from low to high includes it.
By their numbers in this assay, from the lowest: compounds 3, 1 and 2 (each within the scatter of the next).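

In this assay, swapping 2,3-dichlorophenyl for 4-cyanophenyl on a carbon with a double bond to nitrogen can now be read on its own, as a 1.5-fold lower number from compound 2 to compound 3 (0.17 log units; within the scatter), so these two aryl groups are not told apart at this position. Methyl in place of oxolan-3-yl on an oxygen on an aromatic ring can also be read as a single change, as a 1.1-fold lower number from compound 1 to compound 3 (0.05 log units; within the scatter), so these two groups are not told apart at that place either. No measurement on hand bears on the reason for either result.

From the compounds shown here alone, whether an amine chain on that oxygen, or a carboxylic acid on the aryl ring, would give a step beyond the scatter stays open. Also open is how 4-cyanophenyl reads when combined with oxolan-3-yl, as the compounds shown pair it only with methyl.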